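This account rests on a few compounds, and the source may have more. Where it says the series, first, only, none or still open, it means among the compounds named here.

Compound 1 `CCCCNc1nc(N)nc2cccc(C)c12`: 0.3 uM
Compound 2 `CCCCNc1nc(N)nc2cccc(OCCOC)c12`: 0.2 uM
Compound 3 `CCCCNc1nc(N)nc2cccc(C(=O)NC(C)C)c12`: 15.6 uM

These three were measured in an ADME assay on HEK293 cells for agonist activity at Toll-like receptor 8 (Homo sapiens), read by a luciferase reporter, with a stated time of 6 h; a higher number here means that more compound is needed for the effect, a lower number that less compound is needed. Compound 3 stands highest of the three numbers: there was a 52-fold higher number from compound 1 to compound 3 (1.72 log units; beyond the scatter) and a 78-fold higher number from compound 2 to compound 3 (1.89 log units; beyond the scatter), whereas a 1.5-fold lower number from compound 1 to compound 2 (0.18 log units; within the scatter). Compound 4 `CCCCNc1nc(N)nc2cccc(C(=O)N(C)C(C)C)c12` differs from compound 3 by methyl in place of hydrogen on an amide-type nitrogen. For the measured compounds named here, none of the measured steps alters the amide-type nitrogen; the two large steps only show that bringing in the isopropylcarbamoyl group raised the number, and compound 3 already carries it. Going by the values given here, with no measured step bearing directly on this change, no movement beyond the scatter is expected. Compound 4 is therefore estimated at 20 uM, in a range from 7 uM to 60 uM, which is expected to mean a 1.3-fold higher number from compound 3 to compound 4 (0.11 log units; within the scatter).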

Compound 4, minimum effective concentration: > 25 uM
Compound 4: only a limit was reported (the forecaster's own chance of this, stated with the estimate: 15%); at least 1.2-fold (0.09 log units) between middle value and limit.
By their numbers in this assay, from the lowest: compounds 2 and 1 (each within the scatter of the next); then compound 3. At a limit, above all of these: compound 4.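

In this assay compound 4 gives > 25 uM, which is a limit of the assay and not a number. Methyl on the amide-type nitrogen gives an at least 1.6-fold higher number from compound 3 to compound 4 (0.20 log units; that floor lies within the scatter), so this floor does not separate the pair, and the true size of the change stays unknown. The isopropyl(methyl)carbamoyl group still leaves a large gap to the two compounds without an amide, with an at least 120-fold higher number from compound 2 to compound 4 (2.09 log units; beyond the scatter) and an at least 83-fold higher number from compound 1 to compound 4 (1.92 log units; beyond the scatter).

The compounds shown leave open how far the number would rise without the limit. They also leave open whether a plain carbamoyl group or a carboxylic acid in place of the isopropylcarbamoyl group would bring the number down.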